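Methylphenoxy for pyridylmethyl at the two-nitrogen ring carbon

The source may hold more compounds than are shown below. What is called first, only, known or untested is meant among the compounds shown, and "the series" means these compounds.

Measured compounds:
compound 1 `Cc1cccc(Cc2nc3ccc(O[C@H]4CC[C@@H](C(=O)O)CC4)cc3n2C)c1`: > 200000 nM
compound 2 `Cn1c(Cc2cccc(C#N)c2)nc2cc(O[C@H]3CC[C@@H](C(=O)O)CC3)ccc21`: 22000 nM
compound 3 `Cn1c(Cc2cccnc2)nc2cc(O[C@H]3CC[C@@H](C(=O)O)CC3)ccc21`: > 200000 nM

In an assay on isolated protein for inhibition of Long-chain-fatty-acid--CoA ligase 1 (Mus musculus), read by mass spectrometry, with a stated time of 90 min, in the presence of a further agent that is not named here (on this read-out lower numbers stand for stronger inhibition and higher numbers for weaker inhibition), compound 3 gives only a limit, > 200000 nM, and no number. Compound 1 also sits at that limit, which is what the limit of > 200000 nM in this assay, at which 2 of the 3 values shown sit, records. Compound 2 gives a number, 22000 nM, and the step of an at least 9.0-fold higher number from compound 2 to compound 3 (0.95 log units; beyond the scatter) shows the pyridin-3-yl for 3-cyanophenyl exchange carrying the value past the limit.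

Compound 4 `Cc1cccc(Oc2nc3cc(O[C@H]4CC[C@@H](C(=O)O)CC4)ccc3n2C)c1` differs from compound 3 by 3-methylphenoxy in place of (pyridin-3-yl)methyl on an aromatic carbon. Among the compounds with values here, no measured step swaps the single carbon linker for an oxygen linker, so the only bearing evidence is indirect: compound 1, which carries the same 3-methylphenyl ring on a saturated carbon, is itself at the limit. On that basis compound 4 is expected to stay at or near the limit in this assay, with an expected step of a number no higher from compound 3 to compound 4 (the limit leaves the size open) that is essentially none beyond the scatter. The estimate for compound 4 is 200000 nM, ranging from 60000 nM to 700000 nM, with the most likely outcome being that this assay again reports only a limit.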

Compound 4, half-maximal inhibitory concentration: 21000 nM
For compound 4 the middle estimate is 9.5-fold (0.98 log units) above the measured one; measured number outside the range, below it.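

At the ring carbon between two ring nitrogen atoms, 3-methylphenoxy in place of (pyridin-3-yl)methyl gives an at least 9.5-fold lower number from compound 3 to compound 4 (0.97 log units; beyond the scatter), so this position can return a measured number in this assay with an oxygen-linked ring of carbon only. The exchange of 3-cyanobenzyl for 3-methylphenoxy gives a 1.0-fold lower number from compound 2 to compound 4 (0.02 log units; within the scatter), which leaves the two groups indistinguishable here and shows that a measured number at this position does not depend on the benzyl linker or the nitrile. The step from compound 3 gives only a lower bound on the size of the change, because compound 3 stands at a limit of the assay: the limit of > 200000 nM in this assay, at which 2 of the 4 values shown sit.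

Going by these compounds, how much of that step belongs to the oxygen linker and how much to the ring of carbon only remains open, as both change together in this exchange. Also open, on these data alone, is how 3-cyanophenoxy, or an amine linker in place of the oxygen, would read in this assay.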